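This account rests on a few compounds, and the source may have more. Where it says the series, first, only, none or still open, it means among the compounds named here.

Three compounds share one core and differ only in the group on a double-bonded chain carbon. Compound 1 `COc1ccc(/C=C/C(=O)c2ccc(Nc3cc(C)nc4nc(SCc5nc6ccccc6[nH]5)nn34)cc2)cc1F` gives 140 nM in a functional assay on SW-620 cells (Homo sapiens) for cytotoxicity, read by MTT assay, with stated times of 4 h and 72 h, tested at 2 uM; on this read-out higher numbers stand for weaker inhibition and lower numbers for stronger inhibition. Compound 2 `COc1ccc(/C=C/C(=O)c2ccc(Nc3cc(C)nc4nc(SCc5nc6ccccc6[nH]5)nn34)cc2)cc1` gives 170 nM in this assay, and compound 3 `Cc1cc(Nc2ccc(C(=O)/C=C/c3ccc(OC(F)(F)F)cc3)cc2)n2nc(SCc3nc4ccccc4[nH]3)nc2n1` gives 220 nM in this assay. Compound 3 has the highest of the three numbers; its nearest neighbour is compound 2, with a 1.3-fold higher number from compound 2 to compound 3 (0.11 log units; within the scatter), and the furthest is compound 1, with a 1.6-fold higher number from compound 1 to compound 3 (0.20 log units; within the scatter), so all three lie within the scatter of one another.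

Compound 4 `Cc1cc(Nc2ccc(C(=O)/C=C/c3ccccc3Cl)cc2)n2nc(SCc3nc4ccccc4[nH]3)nc2n1` has not yet been measured. It differs from compound 3 in one place: 2-chlorophenyl in place of 4-(trifluoromethoxy)phenyl on a double-bonded chain carbon bound to a double-bonded chain carbon. The two steps that alter the group on the same double-bonded chain carbon, a 1.6-fold higher number from compound 1 to compound 3 (0.20 log units; within the scatter) and a 1.3-fold higher number from compound 2 to compound 3 (0.11 log units; within the scatter), both stayed within the scatter, as did a 1.2-fold higher number from compound 1 to compound 2 (0.08 log units; within the scatter), hydrogen in place of fluoro on an aromatic carbon. Nothing measured here sets a 2-chlorophenyl group apart from the groups already seen, so a step beyond the scatter is not expected. The number for compound 4 in this assay is therefore estimated at 250 nM, with a range from 110 nM to 550 nM. That estimate means an expected step of a 1.1-fold higher number from compound 3 to compound 4 (0.06 log units; within the scatter), which should remain within the scatter.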

Compound 4, half-maximal inhibitory concentration: 680 nM
Beside the measured number, compound 4's estimate is 2.7-fold (0.43 log units) below it; the whole stated range lies below it.
By their numbers in this assay, from the lowest: compounds 1, 2 and 3 (each within the scatter of the next); then compound 4.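

In this assay, the group on a double-bonded chain carbon bound to a double-bonded chain carbon turns out to matter: exchanges among the three earlier groups stayed within the scatter, but 2-chlorophenyl moves the number beyond it (the steps are a 3.1-fold higher number from compound 3 to compound 4 (0.49 log units; beyond the scatter) and a 4.0-fold higher number from compound 2 to compound 4 (0.60 log units; beyond the scatter) and a 4.9-fold higher number from compound 1 to compound 4 (0.69 log units; beyond the scatter)). The position therefore tolerates 4-methoxyphenyl, 3-fluoro-4-methoxyphenyl and 4-(trifluoromethoxy)phenyl alike, while compound 4, the only one of the four carrying chlorine and the only one with no oxygen in this group, gives the weakest inhibition, though each step is modest. No measurement here accounts for this loss, so the change in the group cannot be tied to any particular cause.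

Since 2-chlorophenyl differs from the other groups in several respects at once, the compounds shown do not separate the contribution of the chlorine from that of losing the oxygen-bearing substituent. From the compounds shown here alone, it also remains open where a plain phenyl group, or a phenyl group carrying an amine or a carboxylic acid, would fall relative to these four compounds.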